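Fluorine for two methyls on the anilino ring

The source may hold more compounds than are shown below. What is called first, only, known or untested is meant among the compounds shown, and "the series" means these compounds.

Compound 1 `Cc1ccc(NC2=CC(=O)c3nc4n(c3C2=O)[C@H]2OC[C@@H](O)[C@H]2OC4)cc1C` stands as the lowest number of the three measured compounds in a functional assay on HeLa cells (Homo sapiens) for inhibition, read by sulforhodamine B assay (a lower number here means a stronger inhibitor, a higher number a weaker inhibitor), where compound 1 gives 2690 nM. Compound 2 `Cc1ccc(NC2=CC(=O)c3c(nc4n3[C@H]3OC[C@@H](O)[C@H]3OC4)C2=O)cc1` gives 6590 nM, and compound 3 `O=C1C(NCc2ccccc2)=CC(=O)c2c1nc1n2[C@H]2OC[C@@H](O)[C@H]2OC1` gives 11000 nM. For the measured compounds named here, the one single-point change recorded among them, a 1.7-fold higher number from compound 2 to compound 3 (0.22 log units; within the scatter), shows that swapping the aryl group on the amine nitrogen for a benzyl barely moves the number. Going by the values given here, compound 1 and compound 2 have no step between them, but their two values show that the compound carrying the 3,4-dimethylphenyl gives the lower number.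

Compound 4 `O=C1C=C(Nc2ccccc2F)C(=O)c2c1nc1n2[C@H]2OC[C@@H](O)[C@H]2OC1` differs from compound 1 by 2-fluorophenyl in place of 3,4-dimethylphenyl on an amine nitrogen. With both methyl groups gone and a fluorine in their place, compound 4 is expected to land further from compound 1 than compound 2 does, with an increase in the number, so the expected step is a 3.3-fold higher number from compound 1 to compound 4 (0.52 log units; beyond the scatter). For compound 4 in this assay the estimate is 9000 nM, with a range from 3000 nM to 27000 nM.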

Compound 4, half-maximal inhibitory concentration: 5120 nM
Estimate against measurement, compound 4: 1.8-fold (0.24 log units) above; the range from low to high includes it.
By their numbers in this assay, from the lowest: compounds 1, 4, 2 and 3 (each within the scatter of the next, the first and the last beyond it).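

In this assay, placing 2-fluorophenyl instead of 3,4-dimethylphenyl on the amine nitrogen gives a 1.9-fold higher number from compound 1 to compound 4 (0.28 log units; within the scatter), so compound 1 and compound 4 cannot be told apart. For this pair, the amine nitrogen whose other neighbour is a double-bonded ring carbon tolerates the loss of both methyl groups and the arrival of a fluorine without a change that exceeds the scatter. Nothing available offers a reason for this result.

On these data alone, the methyl groups and the fluorine changed together here, so what each contributes alone remains open. Also open, as far as these compounds go, is how an unsubstituted phenyl, a chlorophenyl or a pyridine ring on the same amine nitrogen would compare with 3,4-dimethylphenyl on the shared core.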